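Swapping 3,4-dichlorophenyl for 4-methylphenyl on a bromoacrylamide series

The source may hold more compounds than are shown below. What is called first, only, known or untested is meant among the compounds shown, and "the series" means these compounds.

In a functional assay on L1210 cells (Mus musculus) for antiproliferative activity, with a stated time of 48 h (a lower number here means a stronger inhibitor, a higher number a weaker inhibitor), compound 1 `C=C(Br)C(=O)Nc1ccc(/C=C/C(=O)c2ccc(F)cc2)cc1` gives 1600 nM, compound 2 `C=C(Br)C(=O)Nc1ccc(/C=C/C(=O)c2ccc(Cl)c(Cl)c2)cc1` gives 2100 nM and compound 3 `C=C(Br)C(=O)Nc1ccc(/C=C/C(=O)c2ccc(Br)cc2)cc1` gives 620 nM. Compound 2 thus sits at the weak end of this small set, and the gap to its nearest neighbour is only a 1.3-fold higher number from compound 1 to compound 2 (0.12 log units; within the scatter). The clear gaps involve the 4-bromophenyl compound: a 3.4-fold lower number from compound 2 to compound 3 (0.53 log units; beyond the scatter), and a 2.6-fold lower number from compound 1 to compound 3 (0.41 log units; beyond the scatter). Compound 4 `C=C(Br)C(=O)Nc1ccc(/C=C/C(=O)c2ccc(C)cc2)cc1` has 4-methylphenyl in place of 3,4-dichlorophenyl on a carbonyl carbon. Among the compounds with values here, no measured compound carries this methyl group, so these steps indicate only a likely size. The step expected is a 1.6-fold lower number from compound 2 to compound 4 (0.21 log units; within the scatter), not beyond the scatter. For compound 4 the estimated value is 1300 nM, with an expected range of 500 nM to 3000 nM.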

Compound 4, half-maximal inhibitory concentration: 1900 nM
The estimate for compound 4 lay 1.5-fold (0.16 log units) below the measured number; the measured number falls inside the stated range.
By their numbers in this assay, from the lowest: compound 3; then compounds 1, 4 and 2 (each within the scatter of the next).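

In this assay, 4-methylphenyl in place of 3,4-dichlorophenyl on the carbonyl carbon makes no real difference (a 1.1-fold lower number from compound 2 to compound 4 (0.04 log units; within the scatter)). Methyl in place of fluoro also stays within the scatter (a 1.2-fold higher number from compound 1 to compound 4 (0.07 log units; within the scatter)), while methyl in place of bromo gives a clearly weaker inhibitor (a 3.1-fold higher number from compound 3 to compound 4 (0.49 log units; beyond the scatter)), so of these four compounds only compound 3 stands apart. Nothing available explains why bromo differs from the other groups. As far as these compounds go, how an amine, a carboxylic acid or a methoxy group would behave on this ring remains open.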